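Does a Chloro Shift Compound 3?

This account rests on a few compounds, and the source may have more. Where it says the series, first, only, none or still open, it means among the compounds named here.

Three related compounds have been measured in a functional assay on A549 cells (Homo sapiens) for antiproliferative activity, read by MTT assay, with a stated time of 48 h; on this read-out lower numbers stand for stronger inhibition and higher numbers for weaker inhibition. There, compound 1 `c1ccc(-c2nn(-c3ccccc3)cc2-c2nc3ccccc3[nH]2)cc1` gives 2710 nM, compound 2 `Clc1ccc2[nH]c(-c3cn(-c4ccccc4)nc3-c3ccccc3)nc2c1` gives 2370 nM, and compound 3 `Fc1ccc(-c2nn(-c3ccccc3)cc2-c2nc3ccccc3[nH]2)cc1` gives 1510 nM. These three values lie within the usual scatter of one another, so compound 3 cannot be ranked apart from the other two.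

Compound 4 `Fc1ccc(-c2nn(-c3ccccc3)cc2-c2nc3cc(Cl)ccc3[nH]2)cc1` keeps all of compound 3 but carries a chloro in place of hydrogen on an aromatic carbon. The closest guide is the same exchange made on compound 1, which gave a 1.1-fold lower number from compound 1 to compound 2 (0.06 log units; within the scatter). The fluoro in place of hydrogen already present in compound 3 gave a 1.8-fold lower number from compound 1 to compound 3 (0.25 log units; within the scatter), so neither exchange has moved the number beyond the scatter. Among the measured compounds shown here, only this one chloro pair is available, and nothing yet shows how the two exchanges behave together. The expected step is small, a 1.2-fold lower number from compound 3 to compound 4 (0.07 log units; within the scatter), with no real change anticipated. Compound 4 is therefore estimated at 1300 nM, with an expected range from 650 nM to 2600 nM.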

Compound 4, half-maximal inhibitory concentration: 1320 nM
For compound 4 the middle estimate is 1.0-fold (0.01 log units) below the measured one; the range from low to high includes it.
By their numbers in this assay, from the lowest: compounds 4, 3, 2 and 1 (each within the scatter of the next, the first and the last beyond it).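

In this assay, the chloro on an aromatic carbon has now been tested on a second core, and a 1.1-fold lower number from compound 3 to compound 4 (0.06 log units; within the scatter) matches its earlier step: the same change on two cores in this assay, a 1.1-fold lower number (0.06 log units; within the scatter) from compound 1 to compound 2 and a 1.1-fold lower number (0.06 log units; within the scatter) from compound 3 to compound 4, 1.0-fold (0.00 log units) apart, within the scatter of two such steps

The fluoro can now be read on a second core too, and a 1.8-fold lower number from compound 2 to compound 4 (0.25 log units; within the scatter) likewise matches its earlier step: the same change on two cores in this assay, a 1.8-fold lower number (0.25 log units; within the scatter) from compound 1 to compound 3 and a 1.8-fold lower number (0.25 log units; within the scatter) from compound 2 to compound 4, 1.0-fold (0.00 log units) apart, within the scatter of two such steps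

The two exchanges therefore sit together in compound 4 with neither visibly altering the step of the other, although every one of these steps lies within the scatter, so neither exchange is shown to change the number at all.

Still open, on these data alone, is whether an amine or a carboxylic acid on this same aromatic carbon would give a step beyond the scatter. Also open, as far as these compounds go, is whether a chloro on another carbon of that ring would behave as this one does.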